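Amine substituent variation on the chlorinated biaryl core

A few compounds are considered here, and "the series" means these few. Any claim that something is new, unique, unknown or untested is made for them only; others in the source may bear on it.

Two compounds of the series have been run in an assay on isolated protein for binding affinity to 5-hydroxytryptamine receptor 1D (Homo sapiens); on this read-out higher numbers stand for weaker inhibition and lower numbers for stronger inhibition. Compound 1 `COc1ccccc1-c1cc(CN(C)C)ccc1Cl` gives 1300 nM. Compound 2 `CNCc1ccc(Cl)c(-c2ccccc2OC)c1`, which carries hydrogen in place of methyl on the amine nitrogen, gives 1200 nM. The step of a 1.1-fold lower number from compound 1 to compound 2 (0.03 log units; within the scatter) is the only measured one so far, and compound 2 sits within the scatter of compound 1, so nothing separates the two on this assay.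

Compound 3 `CCCNCc1ccc(Cl)c(-c2ccccc2OC)c1` is not yet measured. It differs from compound 2 by ethyl in place of hydrogen on a saturated chain carbon bound to an amine nitrogen; read one bond further out, methyl becomes propyl on the amine nitrogen. Going by the values given here, the one step that bears on it, a 1.1-fold lower number from compound 1 to compound 2 (0.03 log units; within the scatter), alters the same amine nitrogen and stays within the scatter, so the amine substituent has not yet moved the number in either direction. No step beyond the scatter is therefore expected for this assay, and the data give no ground for a direction. Compound 3 is estimated at 1200 nM, within 450 nM to 3200 nM. This corresponds to an expected step of no change at the digits printed from compound 2 to compound 3 (within the scatter), essentially flat.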

Compound 3, inhibition constant: 220 nM
Estimate against measurement, compound 3: 5.5-fold (0.74 log units) above, outside the stated range (below it).
By their numbers in this assay, from the lowest: compound 3; then compounds 2 and 1 (each within the scatter of the next).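

The amine nitrogen now proves to be a position that can move the number in this assay: ethyl in place of hydrogen on a saturated chain carbon bound to an amine nitrogen, which reads as methylamino to propylamino, brings a 5.5-fold lower number from compound 2 to compound 3 (0.74 log units; beyond the scatter), whereas the earlier change on that nitrogen gave only a 1.1-fold lower number from compound 1 to compound 2 (0.03 log units; within the scatter). The shift also appears against the dimethylamino compound, with propylamino in place of dimethylamino on a saturated chain carbon bound to an aromatic carbon giving a 5.9-fold lower number from compound 1 to compound 3 (0.77 log units; beyond the scatter), so in these three compounds stronger inhibition goes with the propyl chain whichever of the two earlier amines serves as the reference. No measurement on these compounds accounts for the shift.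

Going by these compounds, with a single propyl example, it remains open whether the number keeps falling with a longer chain such as butyl or pentyl, or whether a branched isopropyl or a cyclopropylmethyl group does the same. A methyl(propyl)amino group on the shared core would show whether the propyl chain still counts when the amine nitrogen no longer carries a hydrogen.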